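Swapping the Ring on the Amide Nitrogen of Compound 1

This account rests on a few compounds, and the source may have more. Where it says the series, first, only, none or still open, it means among the compounds named here.

Compound 1 `CCC/N=C1\S/C(=C\c2ccc(O)c(Cl)c2)C(=O)N1c1ccccc1C`: 79000 nM
Compound 2 `CCC/N=C1\S/C(=C\c2ccc(O)cn2)C(=O)N1c1ccccc1C`: 110000 nM
Compound 3 `CCC/N=C1\S/C(=C\c2ccc(O)c(C#N)c2)C(=O)N1c1ccccc1C`: 220000 nM

In a physicochemical assay for solubility, measured as kinetic solubility (on this read-out lower numbers stand for lower solubility and higher numbers for higher solubility), compound 1 gives 79000 nM, the lowest of the three numbers. The step of a 1.4-fold higher number from compound 1 to compound 2 (0.14 log units; within the scatter) stays within the scatter, while the step of a 2.8-fold higher number from compound 1 to compound 3 (0.44 log units; beyond the scatter) goes beyond it. Compound 4 `CCC/N=C1\S/C(=C\c2ccc(O)c(Cl)c2)C(=O)N1C1CCN(C)C(=O)C1` differs from compound 1 in one place: 1-methyl-2-oxopiperidin-4-yl in place of 2-methylphenyl on an amide-type nitrogen in a ring. None of the three measured steps touches this amide-type nitrogen; all of them alter the other ring, so they give no direct guide to this change. The expectation is therefore tentative: a rise of a 2.5-fold higher number from compound 1 to compound 4 (0.40 log units; beyond the scatter) is estimated for compound 4. Compound 4 is expected to give about 200000 nM, with a range from 60000 nM to 700000 nM.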

Compound 4, solubility: > 250000 nM
Compound 4 ended at the assay's limit; the forecaster's own chance of this, stated with the estimate: 10%; middle value at least 1.2-fold (0.09 log units) away from the limit.
By their numbers in this assay, from the lowest: compounds 1, 2 and 3 (each within the scatter of the next, the first and the last beyond it). At a limit, above all of these: compound 4.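

Compound 4 is the only change shown on this amide-type nitrogen, and 1-methyl-2-oxopiperidin-4-yl in place of 2-methylphenyl gives an at least 3.1-fold higher number from compound 1 to compound 4 (0.50 log units; beyond the scatter). Its step is larger than any printed among compounds 1, 2 and 3, so this position can move the read-out in this assay. Compound 4 sits at a limit, so its true size remains unread: the limit of > 250000 nM in this assay, at which 1 of the 4 values shown sits.

The compounds shown leave open how much of the step belongs to the ring and how much to its carbonyl. A plain cyclohexyl ring, or a ring carrying an amine, could separate the two.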